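Swapping the aryl group on a methylpiperazine oxalamide

The source may hold more compounds than are shown below. What is called first, only, known or untested is meant among the compounds shown, and "the series" means these compounds.

Compound 1 `C[C@@H]1CN(c2ccc(Cl)cc2)CCN1C(=O)C(=O)Nc1ccc2[nH]c(=O)oc2c1` gives 130% in an ADME assay on the whole organism (Rattus norvegicus, strain Sprague-Dawley) for pharmacokinetics, using cassette dosing, at a dose of 1 mg/kg by the oral route; a higher number here means that a larger share of the oral dose reaches the circulation, a lower number that a smaller share of the oral dose reaches the circulation. Compound 3 `C[C@@H]1CN(c2ccc(F)c(F)c2)CCN1C(=O)C(=O)Nc1ccc2[nH]c(=O)oc2c1` gives 118% in this assay. The change between them is 3,4-difluorophenyl in place of 4-chlorophenyl on an amine nitrogen in a ring, and it made the step of a number 12 percentage points lower from compound 1 to compound 3 (beyond the scatter). Compound 2 `C[C@@H]1CN(C(=O)C(=O)Nc2ccc3[nH]c(=O)oc3c2)CCN1c1ccc(Cl)cc1` is built from the same atoms as compound 1, joined differently; the difference between the two cores is not broken down here. In this assay compound 2 gives 52.6%, the lowest of the three numbers. Compound 4 `C[C@@H]1CN(C(=O)C(=O)Nc2ccc3[nH]c(=O)oc3c2)CCN1c1ccc(F)c(F)c1` has not yet been measured. It differs from compound 2 by 3,4-difluorophenyl in place of 4-chlorophenyl on an amine nitrogen in a ring, the same kind of change as that from compound 1 to compound 3, though the place is not identical: in compound 4 the ring nitrogen is next to the ring atom that bears a methyl group, whereas in compound 3 it is two ring bonds from that atom. The step from compound 2 to compound 4 is expected to be a number 10.6 percentage points lower from compound 2 to compound 4 (beyond the scatter), a modest drop like the earlier one, because the step of a number 12 percentage points lower from compound 1 to compound 3 (beyond the scatter) points that way. Compound 4 is therefore estimated at 42%, between 20% and 72%.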

Compound 4, oral bioavailability: 25.3%
The estimate for compound 4 lay 16.7 percentage points above the measured number, within the range that was stated.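

In this assay, 3,4-difluorophenyl in place of 4-chlorophenyl lowered the number on the second core as well, giving a number 27.3 percentage points lower from compound 2 to compound 4 (beyond the scatter). The direction of the change therefore carried over from one core to the other, but its size did not: the same change on two cores in this assay, a number 12 percentage points lower (beyond the scatter) from compound 1 to compound 3 and a number 27.3 percentage points lower (beyond the scatter) from compound 2 to compound 4, 15.3 percentage points apart, beyond the scatter of two such steps What this pair of steps does not show is why the size depends on the core, and two pairs are too few to support a rule for any further core in this series; on this evidence, a step read on one core gives the likely direction on the other but not a reliable size.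

The compounds shown leave open whether the same order would hold for other groups on the amine nitrogen in the ring, such as an unsubstituted phenyl, a 4-methoxyphenyl or a pyridine ring. They also leave open how either core would behave with the methyl group removed or replaced by an ethyl group.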